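The source may report more compounds than this note shows. Statements on the series, on what has been measured and on what is new or still open speak of the compounds shown alone.

Of the compounds shown here, three built on one shared core have been measured in an ADME assay on L929 cells (Mus musculus) for cytotoxicity, read by resazurin assay, with a stated time of 72 h; a higher number here means a weaker inhibitor, a lower number a stronger inhibitor. Compound 1 `O=C(c1ccc(O)cc1)c1ccn(-c2ccc3c(c2)B(O)OC3)c1` gives in this assay only a limit, > 10 ug/mL. Compound 2 `Nc1ccc(C(=O)c2ccn(-c3ccc4c(c3)B(O)OC4)c2)cc1` gives 3.9 ug/mL in this assay. Compound 3 `O=C(CCc1ccccc1)c1ccn(-c2ccc3c(c2)B(O)OC3)c1` likewise reaches only a limit in this assay, > 10 ug/mL. Compound 3 therefore stands at the limit where two of the three values sit (the limit of > 10 ug/mL in this assay, at which 2 of the 3 values shown sit), so its step from compound 1 cannot be read: a step that the two limits leave unreadable from compound 1 to compound 3. Its step from compound 2 is readable in one direction only: an at least 2.5-fold higher number from compound 2 to compound 3 (0.40 log units; beyond the scatter). Among the compounds with values here, the single step between two real numbers, an at least 2.5-fold lower number from compound 1 to compound 2 (0.40 log units; beyond the scatter), concerns a change on a different part of the molecule.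

Compound 4 `CCCCCC(=O)c1ccn(-c2ccc3c(c2)B(O)OC3)c1` differs from compound 3 in the chain hanging from the carbonyl: propyl in place of phenyl on a saturated chain carbon, two bonds along the chain from a carbonyl carbon. Within the data shown here, no measured step exchanges a phenyl for a propyl, so none bears directly on this change. Among the measured compounds shown here, what is known is that compound 3 itself sits at the limit, and that the one readable step leading to it points toward a weaker inhibitor rather than a stronger one. On that basis the expected step is a step that the limit leaves unreadable from compound 3 to compound 4, that is, none beyond the scatter. Compound 4 is thus estimated at 15 ug/mL, with a range from 6 ug/mL to 40 ug/mL.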

Compound 4, half-maximal inhibitory concentration: > 10 ug/mL
Compound 4: a limit, no number (the forecaster's own chance of this, stated with the estimate: 70%); the middle value is on the limit's open side.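

Until now, the only chain on the carbonyl ended in a phenyl ring, so compound 4 adds that a pentyl chain with no ring also leaves the reading at a limit: the limit of > 10 ug/mL in this assay, at which 3 of the 4 values shown sit.

Within the data shown here, compound 2 remains the only compound with a real number, and the pentyl chain gives an at least 2.5-fold higher number from compound 2 to compound 4 (0.40 log units; beyond the scatter), the same direction as the phenethyl chain of compound 3. The steps to compound 4 from compound 1 and from compound 3 cannot be read, as both ends of each step are limits.

As far as these compounds go, how far past the limit compound 1, compound 3 and compound 4 lie remains unknown, so the phenyl and propyl ends cannot be ranked against each other in this assay. From the compounds shown here alone, it also remains open whether a chain ending in an amine or a carboxylic acid, or a shorter or longer plain carbon chain, would give a real number, as compound 2 does.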